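From phenyl to 4-methylphenyl on the shared core

A few compounds are considered here, and "the series" means these few. Any claim that something is new, unique, unknown or untested is made for them only; others in the source may bear on it.

Compound 1 `Nc1ccc2oc(N3CCN(c4ccccc4)CC3)nc2c1` gives 10.3 10^-6 cm/s
Compound 2 `Nc1ccc2oc(N3CCN(c4ccc(Br)cc4)CC3)nc2c1` gives 10.5 10^-6 cm/s

In an ADME assay for permeability, using PAMPA, in phosphate buffer, with a stated time of 18 h, at pH 7.4 (a lower number here means that the compound crosses the layer more slowly, a higher number that the compound crosses the layer faster), compound 1 gives 10.3 10^-6 cm/s and stands level with compound 2 within the scatter. Compound 3 `Cc1ccc(N2CCN(c3nc4cc(N)ccc4o3)CC2)cc1` differs from compound 1 by methyl in place of hydrogen on an aromatic carbon with methyl in place of hydrogen on an aromatic carbon. Among the compounds with values here, the one measured step that bears on this also replaces hydrogen on an aromatic carbon, with bromo, and it stayed within the scatter (a 1.0-fold higher number from compound 1 to compound 2 (0.01 log units; within the scatter)). A single step is thin evidence, but no change beyond the scatter is expected here, so the expected step is small (a 1.0-fold higher number from compound 1 to compound 3 (0.01 log units; within the scatter)). The estimated value for compound 3 is 10.5 10^-6 cm/s (6 10^-6 cm/s to 17 10^-6 cm/s).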

Compound 3, apparent permeability: 10.4 10^-6 cm/s
The estimate for compound 3 lay 1.0-fold (0.00 log units) above the measured number, and the stated range covers the measured number.
By their numbers in this assay, from the lowest: compounds 1, 3 and 2 (each within the scatter of the next).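

In this assay, methyl in place of hydrogen on this aromatic carbon, para to a large group, gives a 1.0-fold higher number from compound 1 to compound 3 (0.00 log units; within the scatter), so a second group here joins bromo in staying within the scatter. Methyl in place of bromo gives a 1.0-fold lower number from compound 2 to compound 3 (0.00 log units; within the scatter), so these two groups cannot be told apart at this position. Nothing available explains this result. From the compounds shown here alone, what a carboxylic acid or a longer chain would do at this position stays open, as does whether either would also stay within the scatter.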